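Notes on the step from compound 2 to compound 4

The source may hold more compounds than are shown below. What is called first, only, known or untested is meant among the compounds shown, and "the series" means these compounds.

Measured so far in a functional assay on BaF3 cells (Mus musculus) for inhibition, read by CCK-8 assay, with a stated time of 72 h; on this read-out higher numbers stand for weaker inhibition of growth and lower numbers for stronger inhibition of growth
Compound 1 `Cc1ccc(NC(=O)Nc2ccc(Oc3cc(/N=C/N(C)C)ncn3)cc2)cc1C(F)(F)F` gives 6610 nM
Compound 2 `CNCCN(C)c1cc(Oc2ccc(NC(=O)Nc3ccc(C)c(C(F)(F)F)c3)cc2)ncn1` gives > 10000 nM
Compound 3 `CC(=O)Nc1cc(Oc2ccc(NC(=O)Nc3cc(-n4cnc(C)c4)cc(C(F)(F)F)c3)cc2)ncn1` gives 1320 nM

Compound 2 gives a limit and no number (the limit of > 10000 nM in this assay, at which 1 of the 3 values shown sits). Compound 4 `Cc1ccc(NC(=O)Nc2ccc(Oc3cc(N4CCN[C@H](C)C4)ncn3)cc2)cc1C(F)(F)F` departs from it by 3-methylpiperazin-1-yl in place of methyl(2-(methylamino)ethyl)amino on an aromatic carbon in the next test. Going by the values given here, one measured step bears on this aromatic carbon, namely an at least 1.5-fold higher number from compound 1 to compound 2 (0.17 log units; that floor lies within the scatter) and it sets only a floor, so its size stays open. Among the compounds with values here, no measured step carries a ring at this place. Compound 1 at 6610 nM shows a number on the same core. In this assay a modest move toward stronger inhibition of growth is expected, estimated as an at least 1.6-fold lower number from compound 2 to compound 4 (0.22 log units; that floor lies within the scatter) and resting on little. For compound 4 the estimated value is 6000 nM within an expected range from 2000 nM to 15000 nM in this read-out.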

Compound 4, concentration for 50% growth inhibition: 8920 nM
For compound 4 the middle estimate is 1.5-fold (0.17 log units) below the measured one, within the range that was stated.
By their numbers in this assay, from the lowest: compound 3; then compounds 1 and 4 (each within the scatter of the next). At a limit, above all of these: compound 2.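

In this assay, 3-methylpiperazin-1-yl on this aromatic carbon gives a measured number on the shared core, whereas compound 2 stands only at a limit: the limit of > 10000 nM in this assay, at which 1 of the 4 values shown sits. Going by these compounds, the ring therefore reads only as an at least 1.1-fold lower number from compound 2 to compound 4 (0.04 log units; that floor lies within the scatter), and the true size of this step stays open. Against the open-chain group of compound 1, the ring gives a 1.3-fold higher number from compound 1 to compound 4 (0.13 log units; within the scatter), so a six-membered non-aromatic ring is tolerated here without a change beyond the scatter.

On these data alone, whether the methyl and its defined stereocentre matter at this place remains open. So does how an unsubstituted piperazine or a morpholine on the same core would read.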